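Amide substituent change on the shared core

The source may hold more compounds than are shown below. What is called first, only, known or untested is meant among the compounds shown, and "the series" means these compounds.

Compound 2 `CCCNC(=O)c1c(NC(=O)NS(=O)(=O)c2ccccc2)sc2c1CCCCC2` in a functional assay on HCC 2998 cells (Homo sapiens) for inhibition, with a stated time of 48 h (on this read-out higher numbers stand for weaker inhibition of growth and lower numbers for stronger inhibition of growth), gives only a limit, > 100000 nM. Compound 1 `NNC(=O)c1c(NC(=O)NS(=O)(=O)c2ccccc2)sc2c1CCCCC2` in this assay gives 900 nM. Among the compounds with values here, the one measured step at the amide nitrogen, an at least 110-fold higher number from compound 1 to compound 2 (2.04 log units; beyond the scatter), is large and runs toward weaker inhibition, ending at the limit of > 100000 nM in this assay, at which 1 of the 2 values shown sits. Compound 3 `O=C(Nc1sc2c(c1C(=O)N1CCN(c3ccccc3)CC1)CCCCC2)NS(=O)(=O)c1ccccc1` carries the change (4-phenylpiperazin-1-yl in place of propylamino on a carbonyl carbon). Within the data shown here, this step bears only indirectly on the new one: the earlier step shows that replacing the amino group on the amide nitrogen costs much, and the new change removes the remaining amide hydrogen as well, which no measured compound covers. On these numbers no shift beyond the scatter is expected in this assay, and a limit may again be reported. Compound 3 is estimated at 80000 nM in this assay, within 10000 nM to 300000 nM. The expected step of an at least 1.2-fold lower number from compound 2 to compound 3 (0.09 log units; that floor lies within the scatter) is thus judged to stay within the scatter.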

Compound 3, concentration for 50% growth inhibition: 16900 nM
For compound 3 the middle estimate is 4.7-fold (0.68 log units) above the measured one; the range from low to high includes it.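

In this assay the carbonyl carbon accepts a much larger group than propylamino: 4-phenylpiperazin-1-yl, which has no amide hydrogen, gives an at least 5.9-fold lower number from compound 2 to compound 3 (0.77 log units; beyond the scatter). That step is only a floor, and the value of compound 2 is a limit: the limit of > 100000 nM in this assay, at which 1 of the 3 values shown sits. Growth inhibition therefore does not depend on an amide hydrogen in compound 3, yet aminoamino remains the better group of the two, with a 19-fold higher number from compound 1 to compound 3 (1.27 log units; beyond the scatter).

Open, as far as these compounds go, is whether the lower number from 4-phenylpiperazin-1-yl belongs to the piperazine ring or to the phenyl ring on it, a question that morpholine or unsubstituted piperazine on the same carbonyl carbon would address. Also open, from the compounds shown here alone, is how dimethylamino, which has neither an amide hydrogen nor a ring, would read in this assay.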